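A few compounds are considered here, and "the series" means these few. Any claim that something is new, unique, unknown or untested is made for them only; others in the source may bear on it.

Series notes, cytotoxicity read-out.

Compound 1, `O=C(NNC(=O)c1cccc([N+](=O)[O-])c1)c1ccc(-n2cccc2)cc1`: 203000 nM
Compound 2, `O=[N+]([O-])c1ccccc1-c1nnc(-c2ccc(-n3cccc3)cc2)o1`: 267000 nM
Compound 3, `CC(=O)NNC(=O)c1ccc(-n2c(C)ccc2C)cc1`: 180000 nM

All three values come from an ADME assay on A549 cells (Homo sapiens) for cytotoxicity, read by MTT assay, with a stated time of 72 h; on this read-out lower numbers stand for stronger inhibition and higher numbers for weaker inhibition. Compound 2 carries the highest of the three numbers, but the gaps to compound 1 and to compound 3 both lie within the scatter, so the three compounds cannot be told apart on this read-out.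

Compound 4, `Brc1ccccc1-c1nnc(-c2ccc(-n3cccc3)cc2)o1`, differs from compound 2 by bromo in place of nitro on an aromatic carbon. For the measured compounds named here, no measured pair in the set changes this position, so there is no reference step. Given that the nitro to bromo change is the only difference and the measured values sit close together, the expected step in this assay is none beyond the scatter, in either direction. For compound 4 the expected value is 250000 nM, with a range from 120000 nM to 500000 nM, which means an expected step of a 1.1-fold lower number from compound 2 to compound 4 (0.03 log units; within the scatter).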

Compound 4, half-maximal inhibitory concentration: 252000 nM
Compound 4: the middle estimate sits 1.0-fold (0.00 log units) below what was measured, and the stated range covers the measured number.
By their numbers in this assay, from the lowest: compounds 3, 1, 4 and 2 (each within the scatter of the next).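

Bromo in place of nitro on an aromatic carbon, ortho to a large group, gives the only reading at this position: in this assay the change amounts to a 1.1-fold lower number from compound 2 to compound 4 (0.03 log units; within the scatter). Nitro and bromo therefore cannot be told apart here, although the earlier compounds gave no step at this position. No measured evidence bears on this result. Going by these compounds, whether an amine or a carboxylic acid at this position would give a step beyond the scatter remains open. A single exchange also says nothing about the other carbons of that ring.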